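The source may hold more compounds than are shown below. What is called first, only, known or untested is meant among the compounds shown, and "the series" means these compounds.

Three compounds have so far been taken through a functional assay on the whole organism (strain Charles Foster albino) for inhibition, with Rattus norvegicus as the target, read by paw edema, with stated times of 30 min and 3 h, at a dose of 50 mg/kg by the oral route; on this read-out higher numbers stand for more inhibition at the one dose given (going by the name of the read-out) and lower numbers for less inhibition. Compound 1 `COc1cc(-c2nc(-c3ccccn3)no2)ccc1O` gives 24% in this assay. Compound 2 `COc1ccc(OC)c(-c2nc(-c3ccccn3)no2)c1` gives 28%, a number within the usual scatter of that of compound 1, and compound 3 `COc1ccc(OC)c(C2CC(c3ccccn3)=NN2)c1` gives 15%, also within the scatter of compound 1. On the bare numbers compound 1 stands second highest of the three, with compound 2 nearest and compound 3 furthest, yet both gaps lie within the scatter, so no ranking of the three follows from them.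

Compound 4 `COc1cc(-c2nc(-c3cnccn3)no2)ccc1O` has not yet been measured. It differs from compound 1 in one place: pyrazin-2-yl in place of pyridin-2-yl on an aromatic carbon. Going by the values given here, no pair of measured compounds that differ in one place is available, so the size of such a step is not known from these data. With all three measured numbers sitting within the scatter of one another, the expected step is a number 1 percentage points higher from compound 1 to compound 4 (within the scatter), which is to say none beyond the scatter and in no set direction. Compound 4 is therefore estimated to give about 25% in this assay, with an expected range from 10% to 40%.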

Compound 4, a percentage reported as inhibition, in the whole organism at one dose (the size of the read-out at that dose, not a potency): 26%
Estimate against measurement, compound 4: 1 percentage points below; measured number inside the range.
By their numbers in this assay, from the lowest: compounds 3, 1, 4 and 2 (each within the scatter of the next, the first and the last beyond it).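

In this assay, going by these compounds alone, the exchange of pyridin-2-yl for pyrazin-2-yl on the aromatic carbon gives a number 2 percentage points higher from compound 1 to compound 4 (within the scatter) and is the first step in one place that can be read. At this position, between two ring nitrogen atoms, a six-membered aromatic ring with 2 hetero atoms thus takes the place of one with 1 hetero atom, with no difference beyond the scatter at the one dose given. Nothing measured on these compounds speaks to the reason for this result.

On these data alone, what an amine, a carboxylic acid or a longer chain would give at this position remains open. So does whether pyrazin-2-yl would read the same way on the core of compound 2 or compound 3.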